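Chain-extended nucleoside analogues: cytotoxicity limits and a longer homologue

The source may hold more compounds than are shown below. What is called first, only, known or untested is meant among the compounds shown, and "the series" means these compounds.

Measured compounds:
- Compound 1 `CCCCCCc1cc2cn([C@H]3C[C@H](O)[C@@H](CO)O3)c(=O)nc2o1`; in a functional assay on HEL cells (Homo sapiens) for cytotoxicity, read by microscopy (a lower number here means that less compound is tolerated, a higher number that more compound is tolerated), compound 1 gives > 50000 nM, a limit of the assay.
- Compound 2 `C=CCCCc1cc2cn([C@H]3C[C@H](O)[C@@H](CO)O3)c(=O)nc2o1`; in this assay compound 2 gives > 200000 nM, a limit of the assay.
- Compound 3 `C=CCCCCCCc1cc2cn([C@H]3C[C@H](O)[C@@H](CO)O3)c(=O)nc2o1`; in this assay compound 3 gives > 200000 nM, a limit of the assay.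

Compound 3 stands at a limit only, as do the other two values shown; none of the three is a number. The steps among the measured compounds are therefore unreadable: a step that the two limits leave unreadable from compound 1 to compound 2, a step that the two limits leave unreadable from compound 1 to compound 3 and a step that the two limits leave unreadable from compound 2 to compound 3 give no size. Among the measured compounds shown here, the only evidence is the limit of > 200000 nM in this assay, at which 2 of the 3 values shown sit, and (the limit of > 50000 nM in this assay, at which 1 of the 3 values shown sits), which say no more than that the tolerated concentrations lie beyond the limits.

Compound 4 `C=CCCCCCCCCc1cc2cn([C@H]3C[C@H](O)[C@@H](CO)O3)c(=O)nc2o1` differs from compound 3 by but-3-en-1-yl in place of vinyl on a saturated chain carbon, six bonds along the chain from an aromatic carbon. For the measured compounds named here, no measured step bears on this change with a readable size, so no direction beyond the scatter can be expected. Compound 4 is expected to give 200000 nM, within 50000 nM to 400000 nM, most likely again only as a limit. The expected step in this assay is estimated at a number no higher from compound 3 to compound 4 (the limit leaves the size open).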

Compound 4, minimum cytotoxic concentration: > 50000 nM
Compound 4: a limit, no number; the forecaster's own chance of this, stated with the estimate: 75%; the middle value lies beyond the limit too.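

In this assay compound 4 gives > 50000 nM, a limit of the assay and not a number. The steps from compound 1, compound 2 and compound 3 to compound 4 join limits only and cannot be read. The compounds shown leave open what concentration any of the four fails to be tolerated at, and whether the chain changes that concentration.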